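The source may report more compounds than this note shows. Statements on the series, on what has been measured and on what is new or still open speak of the compounds shown alone.

Measured compounds in an assay on Sf9 cells for inhibition of serine/threonine-protein kinase 4 (Homo sapiens), read by luminescence and ADP-Glo, with a stated time of 1 h, in the presence of a further agent that is not named here; on this read-out lower numbers stand for stronger inhibition and higher numbers for weaker inhibition:
- compound 1 `CN1CC(=O)N(C)c2cnc(Nc3ccc(S(N)(=O)=O)cc3)nc21` gives 495 nM
- compound 2 `CN1C(=O)C(c2ccccc2)N(C)c2nc(Nc3ccc(S(N)(=O)=O)cc3)ncc21` gives 383 nM
- compound 3 `CN1C(=O)C(c2cccc(C(F)(F)F)c2)N(C)c2nc(Nc3ccc(S(N)(=O)=O)cc3)ncc21` gives 2710 nM

Compound 3 stands at the highest number of the three. Its nearest neighbour is compound 1, with a 5.5-fold higher number from compound 1 to compound 3 (0.74 log units; beyond the scatter); the step of a 7.1-fold higher number from compound 2 to compound 3 (0.85 log units; beyond the scatter) is the larger of the two. Against that, a 1.3-fold lower number from compound 1 to compound 2 (0.11 log units; within the scatter) is within the scatter, so compounds 1 and 2 cannot be told apart here.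

Compound 4 `CN1C(=O)C(c2ccccc2Cl)N(C)c2nc(Nc3ccc(S(N)(=O)=O)cc3)ncc21` has not been measured. Relative to compound 3 the change is 2-chlorophenyl in place of 3-(trifluoromethyl)phenyl on a saturated ring carbon.

Going by the values given here, two measured steps bear on this. The step of a 7.1-fold higher number from compound 2 to compound 3 (0.85 log units; beyond the scatter) shows that placing trifluoromethyl on the phenyl raised the number beyond the scatter; the step of a 1.3-fold lower number from compound 1 to compound 2 (0.11 log units; within the scatter) shows that the bare phenyl itself left the number within the scatter of the unsubstituted parent. Among the compounds with values here, compound 4 carries a different, smaller substituent at a different position on the phenyl, so no measured step maps onto it exactly. The expectation is a number below that of compound 3 but not as low as compound 2, giving for this assay an expected step of a 3.0-fold lower number from compound 3 to compound 4 (0.48 log units; beyond the scatter).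

Compound 4 is therefore estimated at 900 nM in this assay, with a range from 350 nM to 2500 nM.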

Compound 4, half-maximal inhibitory concentration: 129 nM
Estimate against measurement, compound 4: 7.0-fold (0.84 log units) above, outside the stated range (below it).
By their numbers in this assay, from the lowest: compound 4; then compounds 2 and 1 (each within the scatter of the next); then compound 3.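

In this assay the substituent on the phenyl at this saturated ring carbon now moves the number in both directions: chloro in place of hydrogen gives a 3.0-fold lower number from compound 2 to compound 4 (0.47 log units; beyond the scatter) while trifluoromethyl in place of hydrogen gave a 7.1-fold higher number from compound 2 to compound 3 (0.85 log units; beyond the scatter) and so a substituent on that phenyl does not raise the number as such. Going by these compounds alone, compound 4 is also the only aryl compound here to separate from the parent on the low side, with a 3.8-fold lower number from compound 1 to compound 4 (0.58 log units; beyond the scatter) whereas the bare phenyl stayed within the scatter of that parent and the 3-(trifluoromethyl)phenyl went the other way. The direct exchange, a 21-fold lower number from compound 3 to compound 4 (1.32 log units; beyond the scatter) is the largest step in the set, but it changes the group and its place on the phenyl together, and nothing measured on these compounds speaks to why the number moves.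

Still open, from the compounds shown here alone, is how much of that exchange belongs to the chlorine and how much to its place on the ring, which a 3-chlorophenyl or a 2-(trifluoromethyl)phenyl would divide. Also open, going by these compounds, is whether a 2-methoxyphenyl or a 2-aminophenyl at this carbon would track compound 4 or compound 3.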